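This account rests on a few compounds, and the source may have more. Where it says the series, first, only, none or still open, it means among the compounds named here.

In a functional assay on A549 cells (Homo sapiens) for inhibition, read by CCK-8 assay, with a stated time of 72 h, tested at 8 uM (a lower number here means less inhibition of growth, a higher number more inhibition of growth at the concentration tested), compound 2 `Nc1ccccc1NC(=O)c1ccc(CSc2ccc(Br)cc2)cc1` gives 45.7%, the lowest of the three numbers measured, against compound 3 `CC(C)(C)c1ccc(SCc2ccc(C(=O)Nc3ccccc3N)cc2)cc1` at 67% and compound 1 `Cc1ccc(SCc2ccc(C(=O)Nc3ccccc3N)cc2)cc1` at 78.3%. Compound 4 `Cc1cc(C)cc(SCc2ccc(C(=O)Nc3ccccc3N)cc2)c1` is still unmeasured, and its change from compound 2 is 3,5-dimethylphenyl in place of 4-bromophenyl on a sulfur. For the measured compounds named here, two steps bear most directly on this change: a number 32.6 percentage points lower from compound 1 to compound 2 (beyond the scatter) was large, with bromo in place of methyl, and a number 21.3 percentage points higher from compound 2 to compound 3 (beyond the scatter) was modest, with tert-butyl in place of bromo. The third step, a number 11.3 percentage points lower from compound 1 to compound 3 (beyond the scatter), was modest too. Going by the values given here, no measured compound carries the 3,5-dimethylphenyl group, so the evidence is indirect. A modest to large rise is expected in this assay, estimated as a number 22.3 percentage points higher from compound 2 to compound 4 (beyond the scatter). For compound 4 the estimated value is 68%, within an expected range of 52% to 82%.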

Compound 4, percent growth inhibition at one concentration: 78.5%
Beside the measured number, compound 4's estimate is 10.5 percentage points below it, and the stated range covers the measured number.
By their numbers in this assay, from the lowest: compound 2; then compound 3; then compounds 1 and 4 (each within the scatter of the next).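

In this assay the 3,5-dimethylphenyl group on the sulfur brings a number 32.8 percentage points higher from compound 2 to compound 4 (beyond the scatter) and so shows that this position accepts a ring carrying two methyl groups with no loss against one. Set against 4-methylphenyl, the same group gives a number 0.2 percentage points higher from compound 1 to compound 4 (within the scatter) and the two rings cannot be told apart here. No measured evidence accounts for either step. Open, on these data alone, is how a ring with two bromo groups would compare with compound 4, and what an amine or a carboxylic acid on this ring would do.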